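A few compounds are considered here, and "the series" means these few. Any claim that something is new, unique, unknown or untested is made for them only; others in the source may bear on it.

Series of two measured analogues in an ADME assay on HEK-293T cells (Homo sapiens) for cytotoxicity, read by MTT assay, with a stated time of 24 h; a higher number here means that more compound is tolerated, a lower number that less compound is tolerated. Compound 1 `Cc1ccc(-c2nn(-c3ccccc3)cc2-c2nc3ccccc3n2C(=O)c2ccccc2C)cc1` gives 176000 nM. Compound 2 `O=C(c1ccc(Cl)cc1)n1c(-c2cn(-c3ccccc3)nc2-c2ccc(C(F)(F)F)cc2)nc2ccccc21` gives 181000 nM; the two numbers lie within the scatter of each other, so compound 2 stands level with compound 1. Compound 3 `Cc1ccccc1C(=O)n1c(-c2cn(-c3ccccc3)nc2-c2ccc(C(F)(F)F)cc2)nc2ccccc21` is not yet measured. It differs from compound 2 by 2-methylphenyl in place of 4-chlorophenyl on a carbonyl carbon. Compound 1 already carries the (2-methylphenyl)carbonyl, so no step beyond the scatter is expected, with a 1.0-fold lower number from compound 2 to compound 3 (0.01 log units; within the scatter) as the estimated change. Compound 3 is expected to give 178000 nM, in the range 100000 nM to 320000 nM.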

Compound 3, half-maximal cytotoxic concentration: 179000 nM
Compound 3: the middle estimate sits 1.0-fold (0.00 log units) below what was measured; low and high end bracket the measured number.
By their numbers in this assay, from the lowest: compounds 1, 3 and 2 (each within the scatter of the next).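

Going by these compounds alone, at this position, 2-methylphenyl in place of 4-chlorophenyl on a carbonyl carbon gives a 1.0-fold lower number from compound 2 to compound 3 (0.00 log units; within the scatter) in this assay and is the first one-place reading at this carbonyl. Trifluoromethyl in place of methyl on an aromatic carbon gives a 1.0-fold higher number from compound 1 to compound 3 (0.01 log units; within the scatter) and adds a second such reading, so neither change separates the compounds here. No measured evidence bears on these results. 

From the compounds shown here alone, whether an amine or a carboxylic acid in place of the aryl group on the carbonyl carbon would move the number remains open.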